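The source may hold more compounds than are shown below. What is called first, only, known or untested is meant among the compounds shown, and "the series" means these compounds.

Measured so far in an assay for inhibition of prostacyclin synthase (Homo sapiens), using microsomes; on this read-out lower numbers stand for stronger inhibition and higher numbers for weaker inhibition:
- compound 1 `COc1ccc(OC(C)(C)C2OCC(C/C=C\CCC(=O)O)C(c3cccnc3)O2)cc1`: compound 1 gives > 100000 nM, which is a limit of the assay and not a number.
- compound 2 `CC(C)(Cc1ccccc1)C1OCC(C/C=C\CCC(=O)O)C(c2cccnc2)O1`: compound 2 gives 13000 nM.

For the measured compounds named here, compound 2 therefore holds the only real number in this assay. Going by the values given here, the one other value is the limit of compound 1 (the limit of > 100000 nM in this assay, at which 1 of the 2 values shown sits). Among the compounds with values here, the single measured step, an at least 7.6-fold lower number from compound 1 to compound 2 (0.88 log units; beyond the scatter), concerns the group on the saturated chain carbon and is the only comparison available for that part of the molecule.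

Compound 3 `CC(C)(Cc1ccc(F)cc1)C1OCC(C/C=C\CCC(=O)O)C(c2cccnc2)O1` differs from compound 2 by fluoro in place of hydrogen on an aromatic carbon. Within the data shown here, none of the measured steps alters the aromatic ring itself; the step from compound 1 to compound 2 exchanged the whole group on the chain carbon, not a substituent on its ring, so it gives no direct guide to the size of a single fluoro on that ring. The expectation is accordingly a step within the usual scatter in this assay, with no clear direction: a 1.3-fold lower number from compound 2 to compound 3 (0.11 log units; within the scatter). Compound 3 is estimated at 10000 nM, with a range from 4000 nM to 30000 nM.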

Compound 3, half-maximal inhibitory concentration: 2000 nM
Compound 3: middle estimate off by 5.0-fold (0.70 log units), on the high side; measured number below the stated range.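

The aromatic ring of the benzyl group, which the earlier step left unexamined as a site of its own, turns out not to be a silent part of the molecule in this assay: a single fluoro para to a large group gives a 6.5-fold lower number from compound 2 to compound 3 (0.81 log units; beyond the scatter). Exchanging the whole group on the chain carbon for 4-fluorobenzyl gives an at least 50-fold lower number from compound 1 to compound 3 (1.69 log units; beyond the scatter), so the two compounds with a benzyl-type group both stand apart from the 4-methoxyphenoxy compound, and compound 3 carries the lowest number of the three. Compound 1 sits at a limit of the assay and not at a number, so that larger step has no upper end and gives only a lower bound on its size: the limit of > 100000 nM in this assay, at which 1 of the 3 values shown sits.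

On these data alone, only hydrogen and fluoro are compared at this ring place, so it stays open whether chloro, methyl or methoxy there would move the number further, or whether the step belongs to fluoro alone. One pair also cannot show whether the step carries over to other groups on the chain carbon, and 4-fluorophenoxy in place of the 4-methoxyphenoxy of compound 1 would be the matching comparison.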